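The source may hold more compounds than are shown below. What is called first, only, known or untested is meant among the compounds shown, and "the series" means these compounds.

Measured compounds:
compound 1 `Cc1c(NC2=NCCN2)cccc1-c1cccc(F)c1` – 275 nM
compound 2 `COc1cccc(-c2cccc(NC3=NCCN3)c2C)c1` – 43.7 nM

Both were tested in an assay for binding affinity to Adrenergic receptor alpha-1 (Rattus norvegicus); on this read-out higher numbers stand for weaker inhibition and lower numbers for stronger inhibition. Compound 1 gives 275 nM and so has the highest of the two numbers; its nearest neighbour is compound 2, and the step of a 6.3-fold lower number from compound 1 to compound 2 (0.80 log units; beyond the scatter) is beyond the scatter. That step exchanges a fluoro for a methoxy on an aromatic carbon.

Compound 3 `Cc1c(NC2=NCCN2)cccc1-c1cccc(C(F)(F)F)c1` is not yet measured. It differs from compound 1 in one place: trifluoromethyl in place of fluoro on an aromatic carbon. Going by the values given here, no measured step exchanges a fluoro for a trifluoromethyl, so nothing directly tells how this change plays out. The step of a 6.3-fold lower number from compound 1 to compound 2 (0.80 log units; beyond the scatter) only shows that a change at this position can move the number by a modest amount. With no closer comparison, the expected step of a 1.3-fold higher number from compound 1 to compound 3 (0.10 log units; within the scatter) is taken to be small and uncertain in direction, most likely within or near the scatter.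

For compound 3 in this assay the estimate is 350 nM, with a range from 90 nM to 1400 nM.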

Compound 3, inhibition constant: 257 nM
Compound 3: middle estimate off by 1.4-fold (0.13 log units), on the high side; the measured number falls inside the stated range.
By their numbers in this assay, from the lowest: compound 2; then compounds 3 and 1 (each within the scatter of the next).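

Read in this assay, the new step (a 1.1-fold lower number from compound 1 to compound 3 (0.03 log units; within the scatter)) shows that fluoro, with 1 heavy atom, and trifluoromethyl, with 4 heavy atoms, cannot be told apart at this place on the aromatic ring, so the larger count of heavy atoms brings no readable change here. The second step (a 5.9-fold higher number from compound 2 to compound 3 (0.77 log units; beyond the scatter)) shows that methoxy stands apart from trifluoromethyl as well as from fluoro, so among these three groups the lower number belongs to the methoxy compound alone and does not simply follow from replacing fluoro with something larger. Nothing available explains why methoxy differs from the other two groups.

The compounds shown leave open whether a hydroxyl, an ethoxy or an amine at this same place would give a number like that of the methoxy compound or like those of the fluoro and trifluoromethyl compounds. They also leave open whether these three groups would keep the same order at another place on the ring or on a different core.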